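Phenylsulfanyl replaces dimethylpyrazolyl on a shared pyrimidine-free core

The source may hold more compounds than are shown below. What is called first, only, known or untested is meant among the compounds shown, and "the series" means these compounds.

Compound 1 `CCOC(=O)c1cnc(CC)nc1NN1C(=O)C=C(C)C1=O`: 10000 nM
Compound 2 `CCOC(=O)c1cnc(-n2nc(C)cc2C)nc1NN1C(=O)C=C(C)C1=O`: 10000 nM
Compound 3 `CCOC(=O)c1cnc(-c2cccc([N+](=O)[O-])c2)nc1NN1C(=O)C=C(C)C1=O`: 7000 nM

Of the compounds shown here, three of one series have been tested in a functional assay on Jurkat cells for inhibition of nuclear factor NF-kappa-B complex (Homo sapiens); a lower number here means a stronger inhibitor, a higher number a weaker inhibitor. Going by the values given here, compound 2 stands level with compound 1, the two together giving the highest numbers of the three, and its gap to compound 3 is a 1.4-fold lower number from compound 2 to compound 3 (0.15 log units; within the scatter), so no compound separates from the others beyond the scatter.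

The next compound, compound 4 `CCOC(=O)c1cnc(Sc2ccccc2)nc1NN1C(=O)C=C(C)C1=O`, arises from compound 2 by a single exchange: phenylsulfanyl in place of 3,5-dimethyl-1H-pyrazol-1-yl on an aromatic carbon. Among the compounds with values here, no measured step involves a phenylsulfanyl group, so the bearing steps are those that vary the same position: no change at the digits printed from compound 1 to compound 2 (within the scatter), a 1.4-fold lower number from compound 1 to compound 3 (0.15 log units; within the scatter) and a 1.4-fold lower number from compound 2 to compound 3 (0.15 log units; within the scatter). All three lie within the scatter, although none of them swaps in a sulfur-linked ring. On this basis compound 4 is expected to give a number close to that of compound 2, with an expected step of no change at the digits printed from compound 2 to compound 4 (within the scatter). Compound 4 is therefore estimated at 10000 nM in this assay, with a range from 4000 nM to 20000 nM.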

Compound 4, half-maximal inhibitory concentration: 1000 nM
Compound 4: the middle estimate sits 10-fold (1.00 log units) above what was measured, outside the stated range (below it).
By their numbers in this assay, from the lowest: compound 4; then compounds 3, 1 and 2 (each within the scatter of the next).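

In this assay the ethyl, 3,5-dimethyl-1H-pyrazol-1-yl and 3-nitrophenyl groups on this carbon had not separated from one another, whereas phenylsulfanyl gives a 10-fold lower number from compound 2 to compound 4 (1.00 log units; beyond the scatter), along with a 7.0-fold lower number from compound 3 to compound 4 (0.85 log units; beyond the scatter) and a 10-fold lower number from compound 1 to compound 4 (1.00 log units; beyond the scatter), which makes compound 4 the strongest inhibitor of the four. The position, between two ring nitrogen atoms, therefore does respond to the group it carries, and the exchange from compound 2 has this effect with no change in the heavy-atom count of the group. Nothing measured here accounts for the gain. The compounds shown leave open whether it belongs to the sulfur link or to the phenyl ring that the link carries. A phenoxy group, a phenylamino group or a methylsulfanyl group on this carbon would bear on that question.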